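The compounds below may be only part of what the source reports. "The series", "measured", "known", "first", "only" and "open" are said of these compounds alone.

Measured compounds in a functional assay with Homo sapiens as the target; on this read-out lower numbers stand for stronger inhibition and higher numbers for weaker inhibition:

Compound 1 `CC(C)[C@H](NC(=O)COc1cccc2ccccc12)C(=O)N[C@@H](CC(=O)O)C(=O)COc1cccc(C(F)(F)F)c1` gives 16600 nM.
Compound 2 `CC(C)[C@H](NC(=O)COc1cccc2ccccc12)C(=O)N[C@@H](CC(=O)O)C(=O)COc1ccc(Oc2ccccc2)cc1` gives 19000 nM.
Compound 3 `CC(C)[C@H](NC(=O)COc1cccc2ccccc12)C(=O)N[C@@H](CC(=O)O)C(=O)COc1ccccc1F` gives 15700 nM.

All three share one core and differ only in the aryl group on the oxygen on the saturated carbon. Compound 3 sits among them without separating from the others: its distance to compound 1 and to compound 2 lies within the scatter, so the three numbers cannot be ordered with any confidence.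

Compound 4 `CC(C)[C@H](NC(=O)COc1cccc2ccccc12)C(=O)N[C@@H](CC(=O)O)C(=O)COc1cc(F)c(F)cc1F` has not been measured. It differs from compound 3 in one place: 2,4,5-trifluorophenyl in place of 2-fluorophenyl on an oxygen on a saturated carbon.

Within the data shown here, one measured step bears on this change, since it also swaps the aryl group on that same oxygen: a 1.1-fold lower number from compound 1 to compound 3 (0.02 log units; within the scatter). The exchange of 3-(trifluoromethyl)phenyl for 2-fluorophenyl left this assay essentially unmoved, and compound 2 with its phenoxyphenyl group sits in the same band. On that basis the further fluorines of compound 4 are expected to bring no step beyond the scatter in this assay, in either direction.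

Compound 4 is therefore estimated at 15000 nM, with a range from 7000 nM to 32000 nM, which corresponds to an expected step of a 1.0-fold lower number from compound 3 to compound 4 (0.02 log units; within the scatter).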

Compound 4, half-maximal inhibitory concentration: 16700 nM
The estimate for compound 4 lay 1.1-fold (0.05 log units) below the measured number; measured number inside the range.
By their numbers in this assay, from the lowest: compounds 3, 1, 4 and 2 (each within the scatter of the next).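

In this assay, the exchange of 2-fluorophenyl for 2,4,5-trifluorophenyl on the oxygen on a saturated carbon gave a 1.1-fold higher number from compound 3 to compound 4 (0.03 log units; within the scatter) and left the number within the scatter. Among these compounds, the exchange of 3-(trifluoromethyl)phenyl for the same 2,4,5-trifluorophenyl gave a 1.0-fold higher number from compound 1 to compound 4 (0.00 log units; within the scatter) and was just as flat, so the band already seen with the earlier compounds now also holds an aryl group carrying several ring fluorines, and the four compounds still cannot be ordered with any confidence. Nothing available explains why this position stays so flat.

What remains open is whether any group at this place can move the number beyond the scatter, since every group shown is an aryl group on that oxygen. An aryl group bearing an amine or a carboxylic acid, or a saturated chain such as a longer alkyl chain in place of the aryl group, would test whether this flat band extends beyond aryl groups carrying fluorine, trifluoromethyl or phenoxy.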